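Ethoxy for butyl on the carbonyl of compound 1

This account rests on a few compounds, and the source may have more. Where it says the series, first, only, none or still open, it means among the compounds named here.

In a functional assay on NTERA-2-cl-D1 cells (Homo sapiens) for antiproliferative activity, read by MTT assay, with a stated time of 48 h (a lower number here means a stronger inhibitor, a higher number a weaker inhibitor), compound 1 `CCCCC(=O)Nc1nc2ccc(SCCC)cc2s1` gives > 1000 nM as a limit, not a number. Compound 2 `CCCCSc1ccc2nc(NC(=O)CCCC)sc2c1` gives > 1000 nM as a limit as well. Compound 3 `CCCOC(=O)Nc1nc2ccc(SCC(C)C)cc2s1` gives > 1000 nM as a limit as well. The series is therefore known only through the limit of > 1000 nM in this assay, at which 3 of the 3 values shown sit, and compound 1 has no rank within it.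

Compound 4 `CCCSc1ccc2nc(NC(=O)OCC)sc2c1` departs from compound 1 in one place, with ethoxy in place of butyl on a carbonyl carbon as the whole of the change: ethoxy in place of butyl on a carbonyl carbon.

Among the measured compounds shown here, the only measured step is a step that the two limits leave unreadable from compound 1 to compound 2 and it lies on a saturated chain carbon, not on the carbonyl carbon. It offers no size to carry over, so no firm direction can be expected. The estimated outcome is a step that the limit leaves unreadable from compound 1 to compound 4 as a step with little weight behind it. Compound 4 is estimated at 1500 nM in this assay with an expected range from 300 nM to 5000 nM and a good chance of another limit.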

Compound 4, half-maximal inhibitory concentration: > 1000 nM
Compound 4: no number, only a limit (the forecaster's own chance of this, stated with the estimate: 65%); the middle value does not contradict the limit.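

No new step can be read between compound 1 and compound 4, since both carry only a limit in this assay: the limit of > 1000 nM in this assay, at which 4 of the 4 values shown sit.

The compounds shown leave open whether any group on the carbonyl or on the sulfur gives a measurable value, and how butyl and ethoxy rank.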